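Swapping phenylsulfanyl for butylsulfanyl on the cytotoxicity read-out

The source may hold more compounds than are shown below. What is called first, only, known or untested is meant among the compounds shown, and "the series" means these compounds.

Among the measured compounds shown here, compound 2, `Cc1ccc(C(=O)Nc2cc3nc(C4CCCCC4)[nH]c3cc2Sc2ccccc2)cc1`, is the one compound of the pair with a numerical result in an ADME assay on Vero cells (Chlorocebus sabaeus) for cytotoxicity, read by MTT assay, with a stated time of 2 days; on this read-out lower numbers stand for stronger inhibition and higher numbers for weaker inhibition: in this assay compound 2 gives 6250 nM. The other value shown is a limit of the assay rather than a number: compound 1, `CCCCSc1cc2[nH]c(C3CCCCC3)nc2cc1NC(=O)c1ccc(F)cc1F`, reaches > 200000 nM in this assay. Compound 3, `CCCCSc1cc2[nH]c(C3CCCCC3)nc2cc1NC(=O)c1ccc(C)cc1`, has not yet been measured. It differs from compound 2 by butyl in place of phenyl on a sulfur. For the measured compounds named here, no measured pair records this change directly, so its size can only be guessed. Compound 1, which also carries the butylsulfanyl group, sits at the limit of > 200000 nM in this assay, at which 1 of the 2 values shown sits, and that points toward weaker cytotoxicity. The step of a 6.4-fold higher number from compound 2 to compound 3 (0.81 log units; beyond the scatter) is therefore estimated to go toward a higher number, beyond the usual scatter. In this assay compound 3 is expected to come in near 40000 nM, with a likely range from 8000 nM to 200000 nM, and a fair chance that only a limit is reported.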

Compound 3, half-maximal inhibitory concentration: > 200000 nM
Compound 3 was reported as a limit; the forecaster's own chance of this, stated with the estimate: 40%; middle value at least 5.0-fold (0.69 log units) from the limit.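

In this assay, butyl in place of phenyl on a sulfur now has a direct measurement: the change gives an at least 32-fold higher number from compound 2 to compound 3 (1.50 log units; beyond the scatter) with the rest of the structure unchanged. On these data alone, compound 3 gives > 200000 nM as a limit of the assay and not a number, so the true size of this step stays unknown. With butylsulfanyl on the sulfur, the step between compound 1 and compound 3 cannot be read, which leaves the 2,4-difluorophenyl and 4-methylphenyl groups on the carbonyl carbon unseparated at: the limit of > 200000 nM in this assay, at which 2 of the 3 values shown sit.

The compounds shown leave open whether the shift follows from losing the phenyl ring or from the butyl chain itself. A methyl, a cyclohexyl or a benzyl group on the same sulfur, or 2,4-difluorophenyl on the carbonyl carbon alongside phenylsulfanyl, would bear on this.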